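Nitro to chloro on the aryl ring: two amine cores

This account rests on a few compounds, and the source may have more. Where it says the series, first, only, none or still open, it means among the compounds named here.

Compound 1 `COC(=O)C1(c2ccc([N+](=O)[O-])cc2)CC1CN1CCN(c2ccccn2)CC1` and compound 2 `COC(=O)C1(c2ccc(Cl)cc2)CC1CN1CCN(c2ccccn2)CC1` share one core; compound 3 `COC(=O)C1(c2ccc([N+](=O)[O-])cc2)CC1CN1CCC(Cc2ccccc2)CC1` and compound 4 `COC(=O)C1(c2ccc(Cl)cc2)CC1CN1CCC(Cc2ccccc2)CC1` share another. The difference between the two cores is not broken down here. In an assay for displacement of a labelled ligand from Sigma non-opioid intracellular receptor 1 (Cavia porcellus) (a lower number here means a stronger inhibitor, a higher number a weaker inhibitor), compound 1 gives 769 nM, and compound 2 gives 707 nM; the step of a 1.1-fold lower number from compound 1 to compound 2 (0.04 log units; within the scatter) corresponds to chloro in place of nitro on an aromatic carbon. Compound 3 gives 0.68 nM in this assay, far apart from compound 1 and compound 2. Compound 4 carries the same change as compound 2, namely (chloro in place of nitro on an aromatic carbon), applied to the core of compound 3. Because the step of a 1.1-fold lower number from compound 1 to compound 2 (0.04 log units; within the scatter) lies within the scatter, the expected step of a 1.0-fold lower number from compound 3 to compound 4 (0.02 log units; within the scatter) is also small. Compound 4 is therefore estimated at 0.65 nM in this assay, with a range from 0.25 nM to 1.7 nM.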

Compound 4, inhibition constant: 0.82 nM
Estimate against measurement, compound 4: 1.3-fold (0.10 log units) below; measured number inside the range.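

In this assay, chloro in place of nitro on an aromatic carbon gives a 1.2-fold higher number from compound 3 to compound 4 (0.08 log units; within the scatter), and the change reads the same on both cores: the same change on two cores in this assay, a 1.1-fold lower number (0.04 log units; within the scatter) from compound 1 to compound 2 and a 1.2-fold higher number (0.08 log units; within the scatter) from compound 3 to compound 4, 1.3-fold (0.12 log units) apart, within the scatter of two such steps. Across these two cores, then, nitro and chloro at this place can be exchanged with no change beyond the scatter, and the estimate from one core carries to the other. This rests on two pairs only, so it shows no general rule for other cores and gives no reason why the step stays small.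

The compounds shown leave open whether an amine or a carboxylic acid on the same aromatic carbon would behave like nitro and chloro. Going by these compounds, whether the step also holds on a third core remains open too.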